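Lengthening the hydroxyalkyl chain on the shared core

The source may report more compounds than this note shows. Statements on the series, on what has been measured and on what is new or still open speak of the compounds shown alone.

Of the compounds shown here, three sharing one core have been tested in an assay on cells for binding affinity to vitamin D3 receptor (Homo sapiens), read by fluorescence, tested at 1 uM; on this read-out lower numbers stand for less inhibition and higher numbers for more inhibition at the one concentration tested (going by the name of the read-out). Compound 1 `CCC(CC)(c1ccc(OS(=O)(=O)c2ccc(C)cc2)c(C)c1)c1ccc(OCC(O)C(C)(C)C)c(OCC(O)C(C)(C)C)c1` gives 43%, compound 2 `CCC(CC)(c1ccc(OCCO)c(C)c1)c1ccc(OCC(O)C(C)(C)C)c(OCC(O)C(C)(C)C)c1` gives 38%, and compound 3 `CCC(CC)(c1ccc(OCCCCCO)c(C)c1)c1ccc(OCC(O)C(C)(C)C)c(OCC(O)C(C)(C)C)c1` gives 67%, the highest of the three numbers. Its lead over compound 1 is a number 24 percentage points higher from compound 1 to compound 3 (beyond the scatter) and over compound 2 it is a number 29 percentage points higher from compound 2 to compound 3 (beyond the scatter), both beyond the scatter, whereas a number 5 percentage points lower from compound 1 to compound 2 (within the scatter) lies within it.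

Compound 4 `CCC(CC)(c1ccc(OCCCCCCO)c(C)c1)c1ccc(OCC(O)C(C)(C)C)c(OCC(O)C(C)(C)C)c1` has not yet been measured. It differs from compound 3 in one place: hydroxymethyl in place of hydroxy on a saturated chain carbon, five bonds along the chain from an oxygen on an aromatic ring. Going by the values given here, the one measured step that most resembles this is the one from compound 2 to compound 3, where a 3-hydroxypropyl replaced a hydroxy on the same kind of chain and the read-out rose by a number 29 percentage points higher from compound 2 to compound 3 (beyond the scatter). The step from compound 3 to compound 4 is a smaller extension of that same chain, so a gain of similar size seems unlikely, but a small rise or no change beyond the scatter is the more plausible outcome. Compound 4 is therefore expected to give about 70% in this assay, somewhere between 52% and 86%, which would be an estimated step of a number 3 percentage points higher from compound 3 to compound 4 (within the scatter) from compound 3.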

Compound 4, a percentage reported as inhibition, at one concentration (the size of the read-out at that concentration, not a potency): 52%
Estimate against measurement, compound 4: 18 percentage points above; the range from low to high includes it.
By their numbers in this assay, from the lowest: compounds 2, 1 and 4 (each within the scatter of the next, the first and the last beyond it); then compound 3.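

The result shows that lengthening this chain does not keep raising the read-out: in this assay, hydroxymethyl in place of hydroxy, five bonds along the chain from an oxygen on an aromatic ring, gives a number 15 percentage points lower from compound 3 to compound 4 (beyond the scatter), so the 5-hydroxypentyl chain of compound 3 now stands beyond the scatter of all three other compounds, at the top of the series. The 6-hydroxyhexyl chain still keeps part of the gain over the 2-hydroxyethyl chain, with a number 14 percentage points higher from compound 2 to compound 4 (beyond the scatter), while against the (4-methylphenyl)sulfonyl group it gives a number 9 percentage points higher from compound 1 to compound 4 (within the scatter), so the read-out at this position responds to chain length without following a steady trend in either direction. Nothing available here explains why the read-out turns down at this chain length.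

The compounds shown leave open how the 3-hydroxypropyl and 4-hydroxybutyl chains would fall within the rise from the 2-hydroxyethyl to the 5-hydroxypentyl chain, and whether a longer chain such as 7-hydroxyheptyl would lower the number further. They also leave open whether an amine or a carboxylic acid in place of the hydroxy, on the 5-hydroxypentyl length of chain, would hold the read-out of compound 3.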